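The source may report more compounds than this note shows. Statements on the series, on what has been measured and on what is new or still open speak of the compounds shown alone.

Compound 1, `CN(C)c1nc(Cc2c(F)cccc2F)cc(=O)[nH]1`, is measured in an ADME assay on MT4 cells (Homo sapiens) for cytotoxicity, read by MTT assay, with a stated time of 4 days (a lower number here means that less compound is tolerated, a higher number that more compound is tolerated), at > 94000 nM; this value is a limit of the assay rather than a number.
Compound 2, `CC(c1cc(=O)[nH]c(N(C)C)n1)c1c(F)cccc1F`, gives 89000 nM in this assay.
Compound 3, `CCN(C)c1nc(C(C)c2c(F)cccc2F)c(C)c(=O)[nH]1`, gives 81000 nM in this assay.

The change from compound 1 to compound 2 is methyl in place of hydrogen on a saturated chain carbon bound to two aromatic carbons. In this assay the step was an at least 1.0-fold lower number from compound 1 to compound 2 (0.02 log units; that floor lies within the scatter), which the limit of compound 1 leaves open-ended only on one side, as the limit of > 94000 nM in this assay, at which 1 of the 3 values shown sits, shows.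

How the core of compound 3 differs from the core of compound 1 is not broken down here. The numbers for compound 2 and compound 3 sit within the usual scatter of one another, so nothing is read into their order.

Compound 4, `Cc1c(C(C)c2c(F)cccc2F)nc(N(C)C(C)C)[nH]c1=O`, is not yet measured. Set against compound 3, the change is methyl in place of hydrogen on a saturated chain carbon bound to a nitrogen on an aromatic ring and a saturated chain carbon. Among the measured compounds shown here, this is the same kind of change as the one from compound 1 to compound 2, but at a different place: there the carbon carrying the new methyl was bound to two aromatic carbons, here it is bound to a nitrogen on an aromatic ring and a saturated chain carbon.

A step of similar small size is expected, a 1.0-fold lower number from compound 3 to compound 4 (0.01 log units; within the scatter), because an at least 1.0-fold lower number from compound 1 to compound 2 (0.02 log units; that floor lies within the scatter) lay within the scatter and compound 3 starts from 81000 nM. Compound 4 is therefore estimated at 80000 nM, with a range from 40000 nM to 160000 nM.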

Compound 4, half-maximal cytotoxic concentration: > 81000 nM
Compound 4: no number, only a limit; the forecaster's own chance of this, stated with the estimate: 35%; middle value at least 1.0-fold (0.00 log units) from the limit.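

In this assay compound 4 gives > 81000 nM, and this value is a limit of the assay rather than a number. The new step is a number no lower from compound 3 to compound 4 (the limit leaves the size open) and its size therefore cannot be read, and the comparison of this methyl change on the two cores stays unsettled: the same change on two cores in this assay, an at least 1.0-fold lower number (0.02 log units; that floor lies within the scatter) from compound 1 to compound 2 and a number no lower (the limit leaves the size open) from compound 3 to compound 4; the limit leaves it open whether they differ. What the result does show is narrow: on the core of compound 3, turning ethyl into isopropyl in the ethyl(methyl)amino group did not give a lower number, but it does not show that the change has the same effect on different cores, nor how large the effect is on either one.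

The compounds shown leave open what a readable step for this change would look like, and a single pair on each core is too little to establish a rule for the series. They also leave open how this assay would respond if a longer chain, such as butyl, or a ring, such as cyclopropyl, took the place of the isopropyl group on that nitrogen, or if a carboxylic acid or an amine were placed on that chain.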